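A few compounds are considered here, and "the series" means these few. Any claim that something is new, unique, unknown or untested is made for them only; others in the source may bear on it.

Measured compounds:
compound 1, `N#CC1=C(N)Oc2c(c3nc4ccccc4nc3c3ccccc23)C12C(=O)N(Cc1cnnn1-c1cccc(Cl)c1)c1ccccc12`, 35200 nM
compound 2, `N#CC1=C(N)Oc2c(c3nc4ccccc4nc3c3ccccc23)C12C(=O)N(Cc1cnnn1-c1cccc(S(N)(=O)=O)c1)c1ccccc12`, > 50000 nM, a limit of the assay
compound 3, `N#CC1=C(N)Oc2c(c3nc4ccccc4nc3c3ccccc23)C12C(=O)N(Cc1cnnn1-c1cc(Cl)ccc1Cl)c1ccccc12`, > 50000 nM, a limit of the assay

Going by the values given here, in an ADME assay on L02 cells (Homo sapiens) for antiproliferative activity, read by MTT assay, with a stated time of 48 h (on this read-out lower numbers stand for stronger inhibition and higher numbers for weaker inhibition), compound 1 gives 35200 nM, the only number in the set. Compound 2 gives > 50000 nM, which is a limit of the assay. Compound 3 gives > 50000 nM, again a limit of the assay. Among the compounds with values here, compound 1 therefore stands as the sole compound with a readable value, while the limit of > 50000 nM in this assay, at which 2 of the 3 values shown sit, marks where the other two sit.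

Compound 4, `N#CC1=C(N)Oc2c(c3nc4ccccc4nc3c3ccccc23)C12C(=O)N(Cc1cnnn1-c1ccc(Cl)c(Cl)c1)c1ccccc12`, differs from compound 1 by chloro in place of hydrogen on an aromatic carbon. The closest measured step is an at least 1.4-fold higher number from compound 1 to compound 3 (0.15 log units; that floor lies within the scatter), the same kind of change at another place on the ring. Likewise an at least 1.4-fold higher number from compound 1 to compound 2 (0.15 log units; that floor lies within the scatter) ran toward the limit, and a step that the two limits leave unreadable from compound 2 to compound 3. Neither change from compound 1 produced a lower number, so one expects a 1.4-fold higher number from compound 1 to compound 4 (0.15 log units; within the scatter), a step toward higher numbers that may again reach the limit. For compound 4 the estimate is 50000 nM, expected to lie between 25000 nM and 100000 nM.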

Compound 4, half-maximal inhibitory concentration: > 50000 nM
Compound 4: only a limit was reported; the forecaster's own chance of this, stated with the estimate: 60%; the middle value lies on the limit itself.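

A chloro at this position, ortho to the chloro group already present in compound 1 and para to a large group, gives an at least 1.4-fold higher number from compound 1 to compound 4 (0.15 log units; that floor lies within the scatter) in this assay, so a second chloro placed here did not produce a lower number, just as the second chloro of compound 3 did not. Going by these compounds, the value of compound 4 is a limit of the assay and not a number, so the true size of the step is unknown, and the steps among compounds 2, 3 and 4 cannot be read. Going by these compounds alone, compound 1 remains the only compound with a readable number, and the others share one mark: the limit of > 50000 nM in this assay, at which 3 of the 4 values shown sit.

On these data alone, whether a methyl or an amine at this position would give a lower number remains open. Also open, as far as these compounds go, is how far compound 4 lies from compound 1.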